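Inverting Configuration on a Methoxycyclohexyl Substituent

The compounds below may be only part of what the source reports. "The series", "measured", "known", "first", "only" and "open" are said of these compounds alone.

Measured compounds:
compound 1, `CC(C)(O)c1ccc(-c2cnc3c(n2)N(CC2CCOCC2)C(=O)CN3)cn1`: 86%
compound 2, `CO[C@H]1CC[C@@H](N2CC(=O)Nc3ncc(-c4ccc(C(C)(C)O)nc4)nc32)CC1`: 34%

In a functional assay on the whole organism (PC-3 cells) for inhibition, with Mus musculus as the target, in a xenograft, with a stated time of 4 h, at a dose of 100 mg/kg by the oral route (a lower number here means less inhibition, a higher number more inhibition at the dose given (going by the name of the read-out)), compound 1 gives 86%, while compound 2 gives 34%, the lowest of the two numbers and a gap beyond the scatter to compound 1. Compound 3, `CO[C@H]1CC[C@H](N2CC(=O)Nc3ncc(-c4ccc(C(C)(C)O)nc4)nc32)CC1`, has not been measured. Its relation to compound 2 is the two compounds have the same atoms and bonds and differ only in configuration as drawn: 2 of 2 stereo elements differ (all stereocentres are inverted: mirror images); a stereocentre at a saturated ring carbon is drawn s in compound 2 and r in compound 3; a stereocentre at a saturated ring carbon is drawn s in compound 2 and r in compound 3. Among the compounds with values here, no measured pair shows such a change, so the direction cannot be read from the data. Compound 3 is expected to give 50%, within 15% to 85%, an estimated step of a number 16 percentage points higher from compound 2 to compound 3 (beyond the scatter) that could fall either way.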

Compound 3, a percentage reported as inhibition, in the whole organism at one dose (the size of the read-out at that dose, not a potency): 62%
Compound 3: middle estimate off by 12 percentage points, on the low side, within the range that was stated.
By their numbers in this assay, from the lowest: compound 2; then compound 3; then compound 1.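

Within the data shown here, until now no measured pair isolated configuration on this cyclohexyl substituent, and here inverting both stereocentres while keeping the same atoms and bonds gives, in this assay, a number 28 percentage points higher from compound 2 to compound 3 (beyond the scatter). The methoxycyclohexyl position is therefore sensitive to how the substituent is drawn in space, not only to which atoms it carries. The step can be assigned to configuration alone because nothing else separates the pair: the fact that compounds 2 and 3 differ only in the configuration as drawn

The compounds shown leave open whether a hydroxyl group or an amine in place of the methoxy would show the same dependence on configuration. They also do not tell how this step arises in the animal.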